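The source may hold more compounds than are shown below. What is called first, only, known or untested is meant among the compounds shown, and "the series" means these compounds.

Measured so far in an ADME assay on L929 cells (Mus musculus) for cytotoxicity, read by CCK-8 assay, with a stated time of 48 h, tested at 100 uM; on this read-out lower numbers stand for a stronger effect and higher numbers for a weaker effect at the one concentration tested:
- compound 1 `COc1ccc(S(=O)(=O)N2CCN(Cc3ccccc3)CC2)cc1S(=O)(=O)N1CCN(Cc2ccccc2)CC1` gives 22.2%
- compound 2 `CCOc1ccc(S(=O)(=O)N2CCN(c3cccc(C)c3)CC2)cc1S(=O)(=O)N1CCN(c2cccc(C)c2)CC1` gives 33.3%
- compound 3 `CCOc1ccc(S(=O)(=O)N2CCN(c3ccccc3F)CC2)cc1S(=O)(=O)N1CCN(c2ccccc2F)CC1` gives 3.7%

Compound 2 stands highest of the three numbers in this assay, the weakest effect seen; compound 1 lies below it beyond the scatter, and compound 3 lies furthest below, also beyond the scatter. Among the measured compounds shown here, no pair of measured compounds differs in one place, so no step size is established.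

Compound 4 `COc1ccc(S(=O)(=O)N2CCN(c3cccc(C)c3)CC2)cc1S(=O)(=O)N1CCN(c2cccc(C)c2)CC1` is not yet measured. It differs from compound 2 by hydrogen in place of methyl on a saturated chain carbon bound to an oxygen on an aromatic ring. For the measured compounds named here, no matched step shows what this change does in this assay, so the expectation is a step within the scatter, in no settled direction. The estimate for compound 4 is 30%, range 12% to 55%. This means an expected step of a number 3.3 percentage points lower from compound 2 to compound 4 (within the scatter).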

Compound 4, a percentage reported as activity, at one concentration (the size of the read-out at that concentration, not a potency): 66.7%
Beside the measured number, compound 4's estimate is 36.7 percentage points below it; measured number outside the range, above it.
By their numbers in this assay, from the lowest: compound 3; then compound 1; then compound 2; then compound 4.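

In this assay, the saturated chain carbon bound to an oxygen on an aromatic ring proves a sensitive place: ethoxy to methoxy gives a number 33.4 percentage points higher from compound 2 to compound 4 (beyond the scatter) with nothing else altered. This first matched pair shows that removing one methyl here weakens the effect at the one concentration tested, by far more than the usual scatter. No measurement at hand accounts for this step.

From the compounds shown here alone, whether methoxy gives a similar step alongside the other groups in compound 1 and compound 3 remains open. So does the outcome with a longer chain, such as propoxy, in this place.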